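Triterpenoid esters: a nitrophenyl ester expected from an acetate

The compounds below may be only part of what the source reports. "The series", "measured", "known", "first", "only" and "open" are said of these compounds alone.

Measured compounds:
- compound 1 `CC(=O)O[C@H]1CC[C@]2(C)[C@H](CC[C@@](C)(O)[C@H]2CC[C@@H]2C(C)=CC[C@H]3[C@H](CC[C@]3(C)O)C2(C)C)OC1(C)C`, 38000 nM
- compound 2 `CC(=O)O[C@H]1CC[C@]2(C)[C@H](CC[C@@](C)(O)[C@H]2CC[C@@H]2C(C)=CC[C@@H]3C(C)=CC[C@@H]3C2(C)C)OC1(C)C`, 39200 nM
- compound 3 `CC1=CC[C@H]2[C@@H]1CC=C(C)[C@@H](CC[C@H]1[C@]3(C)CC[C@H](OC(=O)c4ccccc4)C(C)(C)O[C@H]3CC[C@@]1(C)O)C2(C)C`, 18400 nM

In a functional assay on MDA-MB-231 cells (Homo sapiens) for antiproliferative activity, read by MTT assay, with a stated time of 72 h (a lower number here means a stronger inhibitor, a higher number a weaker inhibitor), compound 1 gives 38000 nM, the second highest of the three numbers, and it sits within the scatter of compound 2, which gives 39200 nM. Compound 3, with 18400 nM, is the only one of the three clearly apart from compound 1, with a lower number.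

Compound 4 `CC1=CC[C@H]2[C@H](CC[C@]2(C)O)C(C)(C)[C@@H]1CC[C@H]1[C@]2(C)CC[C@H](OC(=O)c3ccccc3[N+](=O)[O-])C(C)(C)O[C@H]2CC[C@@]1(C)O` has not been measured. It differs from compound 1 in one place: 2-nitrophenyl in place of methyl on a carbonyl carbon.

Among the compounds with values here, one measured step bears on this. It is a 2.1-fold lower number from compound 2 to compound 3 (0.33 log units; beyond the scatter), where an aromatic ring likewise replaces the methyl on the carbonyl carbon. Within the data shown here, the ring entering compound 4 additionally carries a nitro group, for which no measured pair gives guidance, so the expectation rests on that single step alone. A modest lowering of the number, of similar size, is therefore expected, giving a 1.9-fold lower number from compound 1 to compound 4 (0.28 log units; within the scatter) as the estimated step. Compound 4 is expected to give about 20000 nM, within a range from 8000 nM to 50000 nM.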

Compound 4, half-maximal inhibitory concentration: 38700 nM
Compound 4: the middle estimate sits 1.9-fold (0.29 log units) below what was measured; low and high end bracket the measured number.
By their numbers in this assay, from the lowest: compound 3; then compounds 1, 4 and 2 (each within the scatter of the next).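

In this assay, the step of a 1.0-fold higher number from compound 1 to compound 4 (0.01 log units; within the scatter) shows that replacing the small methyl on this carbonyl carbon with the much larger 2-nitrophenyl leaves the number unchanged, so this place accepts a bulky aromatic group without any measurable gain or loss. An aromatic ring here therefore does not always bring the lower number seen in the step of a 2.1-fold lower number from compound 2 to compound 3 (0.33 log units; beyond the scatter), which was taken on a different core. Nothing available explains this difference between the two steps.

The compounds shown cannot separate the nitro group from the change of core, since neither a plain phenyl on the core of compound 1 nor a 2-nitrophenyl on the core of compound 2 appears among them. On these data alone, how a longer chain or a ring carrying an amine would behave on this carbonyl carbon also remains open.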